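Aryl amide variation in the series

The source may report more compounds than this note shows. Statements on the series, on what has been measured and on what is new or still open speak of the compounds shown alone.

Measured so far:
Compound 1 `O=C(Cn1c(=O)c(/C=C\c2ccncc2)nc2ccccc21)Nc1ccccc1` gives > 100000 nM in a functional assay on cells (Homo sapiens) for inhibition, read by MTT assay, with a stated time of 24 h (a lower number here means a stronger inhibitor, a higher number a weaker inhibitor), which is a limit of the assay.
Compound 2 `O=C(Cn1c(=O)c(/C=C\c2ccncc2)nc2ccccc21)Nc1ccc(Cl)cc1` gives > 100000 nM in this assay, also a limit of the assay.

Compound 2 stands at the limit (the limit of > 100000 nM in this assay, at which 2 of the 2 values shown sit), so its place among the numbers is known only as a limit. The step that the two limits leave unreadable from compound 1 to compound 2 is accordingly unreadable in size. Compound 3 `COc1ccc(NC(=O)Cn2c(=O)c(/C=C\c3ccncc3)nc3ccccc32)cc1OC` differs from compound 2 by 3,4-dimethoxyphenyl in place of 4-chlorophenyl on an amide-type nitrogen. Among the compounds with values here, no measured step bears readably on this change, so no direction can be expected beyond the scatter. Compound 3 is expected to remain near the limit, the step that the limit leaves unreadable from compound 2 to compound 3 being an estimate only. Compound 3 is estimated at 200000 nM, ranging from 50000 nM to 1000000 nM.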

Compound 3, half-maximal inhibitory concentration: > 100000 nM
Compound 3: only a limit was reported; the forecaster's own chance of this, stated with the estimate: 80%; the middle value is on the limit's open side.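

Within the data shown here, compound 1, compound 2 and compound 3 all stand at a limit in this assay, and no step among them can be read: the limit of > 100000 nM in this assay, at which 3 of the 3 values shown sit. The compounds shown leave open whether any aryl group on the amide-type nitrogen gives a readable value.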